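This account rests on a few compounds, and the source may have more. Where it says the series, first, only, none or still open, it means among the compounds named here.

Compound 3 `Cc1cc2ccc(C#N)cc2c(C)c1Oc1ccccc1OCCn1ccc(=O)[nH]c1=O` gives 5000 nM in a toxicity assay on MT2 cells (Homo sapiens) for cytotoxicity, read by MTT assay (a lower number here means that less compound is tolerated, a higher number that more compound is tolerated), the lowest of the two numbers shown. Compound 1 `Cc1cc(Oc2ccccc2OCCn2ccc(=O)[nH]c2=O)cc2cc(C#N)ccc12` gives 6000 nM in this assay, which lies within the scatter of compound 3. For compound 2 `Cc1cc(Oc2ccccc2OCCn2ccc(=O)[nH]c2=O)c(C)c2cc(C#N)ccc12` this assay reports only a limit, > 100000 nM. Compound 4 `Cc1c(Oc2ccccc2OCCn2ccc(=O)[nH]c2=O)c(C)c2cc(C#N)ccc2c1C` differs from compound 3 by methyl in place of hydrogen on an aromatic carbon. Among the compounds with values here, one measured step bears on this change: an at least 16-fold higher number from compound 1 to compound 2 (1.22 log units; beyond the scatter), where a methyl likewise took the place of a hydrogen on an aromatic carbon and the number reached (the limit of > 100000 nM in this assay, at which 1 of the 3 values shown sits). A step in the same upward direction is therefore expected for compound 4, with a real chance that this assay again returns only a limit. The estimate for compound 4 is 40000 nM, with a range from 8000 nM to 150000 nM. This expected value means an 8.0-fold higher number from compound 3 to compound 4 (0.90 log units; beyond the scatter).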

Compound 4, half-maximal cytotoxic concentration: > 100000 nM
Compound 4: no number, only a limit; the forecaster's own chance of this, stated with the estimate: 40%; middle value at least 2.5-fold (0.39 log units) away from the limit.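

On the core of compound 3, methyl in place of hydrogen on an aromatic carbon also gives a large step (an at least 20-fold higher number from compound 3 to compound 4 (1.30 log units; beyond the scatter)), so the rise in this assay now appears on two cores: the same change on two cores in this assay, an at least 16-fold higher number (1.22 log units; beyond the scatter) from compound 1 to compound 2 and an at least 20-fold higher number (1.30 log units; beyond the scatter) from compound 3 to compound 4; the limit leaves it open whether they differ.
Compound 4 gives only a limit, and the values shown now pile up there: the limit of > 100000 nM in this assay, at which 2 of the 4 values shown sit.
The step between compound 2 and compound 4 cannot be read, as both values are limits.

From the compounds shown here alone, the true size of the two large steps stays open. Going by these compounds, whether an ethyl or a chlorine at this position would also raise the number in this assay remains open too.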